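The compounds below may be only part of what the source reports. "The series", "measured", "known", "first", "only" and "open" are said of these compounds alone.

Measured so far:
Compound 1, `CCN(CC)C(=O)c1cc2cc(C)ccc2n1Cc1ccc(O)cc1`, gives only a limit in an assay on HEK293 cells for displacement of a labelled ligand from Translocator protein (Homo sapiens), read by scintillation counting, with a stated time of 90 min (a lower number here means a stronger inhibitor, a higher number a weaker inhibitor), > 10000 nM.
Compound 2, `COc1ccc(CN(C(C)=O)c2cc(C)cc(C)c2)cc1`, gives 2790 nM in this assay.
Compound 3, `CCN(CC)C(=O)CN(Cc1ccccc1)c1cc(C)cc(C)c1`, gives 4260 nM in this assay.

Compound 3 carries the higher of the two numbers that were actually read in this assay. Its nearest neighbour is compound 2, whose value of 2790 nM lies a gap away that falls within the usual scatter of repeated measurements, so no order between compound 2 and compound 3 can be claimed from these figures. Of the three results shown, one sits at the limit of > 10000 nM in this assay, at which 1 of the 3 values shown sits, and that one belongs to compound 1.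

Compound 4, `CCN(CC)C(=O)CN(Cc1ccc(OC)cc1)c1cc(C)cc(C)c1`, has not yet been measured. It differs from compound 3 in a single place: methoxy in place of hydrogen on an aromatic carbon. Among the compounds with values here, no pair of measured compounds shows this same change, so there is no measured step to lean on, and the other two compounds differ from compound 3 in more than one place. The expectation therefore rests on compound 3 alone, and the step is expected to stay within the scatter or to lower the number only slightly.

Compound 4 is thus expected to give about 3000 nM in this assay, with a range from 1000 nM to 10000 nM. The estimated step of a 1.4-fold lower number from compound 3 to compound 4 (0.15 log units; within the scatter) is expected to be small.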

Compound 4, inhibition constant: 4210 nM
Compound 4: the middle estimate sits 1.4-fold (0.15 log units) below what was measured; measured number inside the range.
By their numbers in this assay, from the lowest: compounds 2, 4 and 3 (each within the scatter of the next). At a limit, above all of these: compound 1.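

In this assay, within the data shown here, phenyl to 4-methoxyphenyl, with the methoxy on an aromatic carbon para to a large group, gives a 1.0-fold lower number from compound 3 to compound 4 (0.01 log units; within the scatter) and is the first single-place comparison at this position, where the two forms cannot be told apart. A second single-place comparison appears with the 4-methoxyphenyl group kept: (diethylcarbamoyl)methyl in place of acetyl on the nitrogen gives a 1.5-fold higher number from compound 2 to compound 4 (0.18 log units; within the scatter) and likewise separates neither compound from the other, so neither substituent on that nitrogen can be ranked from these figures. No measurement shown here speaks to what lies behind either result.

Going by these compounds, whether this position stays as undemanding for other groups remains open, since a single methoxy cannot say how a carboxylic acid, an amine, a fluorine atom or a longer chain such as butoxy would read there. Also open, on these data alone, is whether any replacement on the nitrogen, such as a longer amide chain or a chain ending in a carboxylic acid, would carry a compound beyond the scatter of the values seen so far.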